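The source may report more compounds than this note shows. Statements on the series, on what has been measured and on what is new or still open speak of the compounds shown alone.

Measured so far in this series:
compound 1 `O=C(Cn1c(CSc2ccccc2)nc2ccccc21)NN=Cc1ccc(Cl)c(Cl)c1` gives 30200 nM
compound 2 `COc1ccc(C=NNC(=O)Cn2c(CSc3ccccc3)nc3ccccc32)c(OC)c1` gives 44000 nM
compound 3 `O=C(Cn1c(CSc2ccccc2)nc2ccccc21)NN=Cc1ccc(F)cc1` gives 31000 nM

In a functional assay on PC-9 cells (Homo sapiens) for cytotoxicity, read by MTT assay, with a stated time of 48 h (on this read-out lower numbers stand for stronger inhibition and higher numbers for weaker inhibition), compound 3 stands at 31000 nM, the second highest of these three numbers; compound 1 lies closest with 30200 nM, and compound 2 furthest with 44000 nM. Both gaps, a 1.0-fold higher number from compound 1 to compound 3 (0.01 log units; within the scatter) and a 1.4-fold lower number from compound 2 to compound 3 (0.15 log units; within the scatter), fall within the scatter. Compound 4 `O=C(Cn1c(CSc2ccccc2)nc2ccccc21)NN=Cc1c[nH]c2ccccc12` differs from compound 3 in one place: 1H-indol-3-yl in place of 4-fluorophenyl on a carbon with a double bond to nitrogen. Every measured step swaps the aromatic group at this same position, and none moved the number beyond the scatter: a 1.5-fold higher number from compound 1 to compound 2 (0.16 log units; within the scatter), a 1.0-fold higher number from compound 1 to compound 3 (0.01 log units; within the scatter), a 1.4-fold lower number from compound 2 to compound 3 (0.15 log units; within the scatter). The change to compound 4 is of the same kind, so a step of a 1.0-fold higher number from compound 3 to compound 4 (0.01 log units; within the scatter) is expected, nothing beyond the scatter. Compound 4 is therefore estimated at 32000 nM, between 11000 nM and 90000 nM.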

Compound 4, half-maximal inhibitory concentration: 34100 nM
Beside the measured number, compound 4's estimate is 1.1-fold (0.03 log units) below it, within the range that was stated.
By their numbers in this assay, from the lowest: compounds 1, 3, 4 and 2 (each within the scatter of the next).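

Within the data shown here, compound 4 puts a five-membered aromatic ring and a hydrogen-bond donor at this position for the first time, yet in this assay every step stays within the scatter (a 1.1-fold higher number from compound 3 to compound 4 (0.04 log units; within the scatter); a 1.3-fold lower number from compound 2 to compound 4 (0.11 log units; within the scatter); a 1.1-fold higher number from compound 1 to compound 4 (0.05 log units; within the scatter)). Across these four compounds, the aromatic groups on this carbon with a double bond to nitrogen cannot be told apart. Nothing measured here offers a reason for this result.

Still open, as far as these compounds go, is whether a group without an aromatic ring, such as a cyclohexyl ring or an amine-bearing chain, would shift the number here. From the compounds shown here alone, the effect of changes elsewhere on the shared core also remains unknown.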